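Aryl swap on the ring nitrogen: compound 3 to compound 4

The compounds below may be only part of what the source reports. "The series", "measured", "known", "first", "only" and "open" are said of these compounds alone.

Measured in a functional assay on A549 cells (Homo sapiens) for antiproliferative activity, read by MTT assay, with a stated time of 72 h; a higher number here means a weaker inhibitor, a lower number a stronger inhibitor:
- compound 1 `Nc1nc(N)c2cc(CSC(=S)N3CCN(c4ccc(O)cc4)CC3)ccc2n1`: 4210 nM
- compound 2 `Cc1ccccc1N1CCN(C(=S)SCc2ccc3nc(N)nc(N)c3c2)CC1`: 3920 nM
- compound 3 `Nc1nc(N)c2cc(CSC(=S)N3CCN(c4ccc(F)cc4)CC3)ccc2n1`: 2040 nM

Compound 3 gives 2040 nM and is separated from the other two only by small steps. The step of a 1.9-fold lower number from compound 2 to compound 3 (0.28 log units; within the scatter) stays within the scatter, while a 2.1-fold lower number from compound 1 to compound 3 (0.31 log units; beyond the scatter) only just passes it.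

Compound 4 `Nc1nc(N)c2cc(CSC(=S)N3CCN(c4ccccn4)CC3)ccc2n1` carries pyridin-2-yl in place of 4-fluorophenyl on an amine nitrogen in a ring.

All three measured steps change the group at this same place, and the third, a 1.1-fold lower number from compound 1 to compound 2 (0.03 log units; within the scatter), is also within the scatter. For the measured compounds named here, none of the measured compounds has a hetero atom in this aromatic ring, so the series gives no direct precedent. With changes here moving this assay so little, only a small step is expected, with a slight lean towards a higher number. The expected step is a 1.5-fold higher number from compound 3 to compound 4 (0.17 log units; within the scatter), which would not clearly leave the scatter. Compound 4 is estimated at 3000 nM, with an expected range of 1400 nM to 6500 nM.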

Compound 4, half-maximal inhibitory concentration: 3960 nM
The estimate for compound 4 lay 1.3-fold (0.12 log units) below the measured number, within the range that was stated.
By their numbers in this assay, from the lowest: compounds 3, 2, 4 and 1 (each within the scatter of the next, the first and the last beyond it).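

In this assay, pyridin-2-yl, the only aromatic ring here with a hetero atom, stays within the scatter of all three carbon-only rings: a 1.9-fold higher number from compound 3 to compound 4 (0.29 log units; within the scatter), a 1.0-fold higher number from compound 2 to compound 4 (0.00 log units; within the scatter) and a 1.1-fold lower number from compound 1 to compound 4 (0.03 log units; within the scatter). Placing a hydrogen-bond acceptor in this ring therefore produces no clear step from 4-fluorophenyl, and the only step beyond the scatter at this place remains a 2.1-fold lower number from compound 1 to compound 3 (0.31 log units; beyond the scatter). Nothing available bears on why these values sit so close together.

As far as these compounds go, whether this place stays as flat without an aromatic ring, with cyclohexyl or acetyl on the ring nitrogen, or with a carboxylic acid on the aromatic ring, remains open. All four compounds share the same core, so the effect of changes elsewhere is also unknown.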